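Iodo for bromo beside an acetamido group

A few compounds are considered here, and "the series" means these few. Any claim that something is new, unique, unknown or untested is made for them only; others in the source may bear on it.

The series rests on two anilines and an acetanilide that share one core. Compound 1 `Nc1ccc(-c2nc3ccccc3s2)cc1Br` carries bromo, compound 2 `Nc1ccc(-c2nc3ccccc3s2)cc1I` carries iodo, and compound 3 `CC(=O)Nc1ccc(-c2nc3ccccc3s2)cc1Br` is the acetylated counterpart of compound 1. In a functional assay on MDA-MB-468 cells (Homo sapiens) for antiproliferative activity (on this read-out lower numbers stand for stronger inhibition and higher numbers for weaker inhibition), compound 1 gives < 1 nM, which is a limit of the assay and not a number. In this assay compound 2 likewise gives < 1 nM, again a limit. For compound 3 this assay reports > 100 nM, also a limit.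

From compound 1 to compound 2 the change is iodo in place of bromo on an aromatic carbon, and this gives a step that the two limits leave unreadable from compound 1 to compound 2, because the limit of < 1 nM in this assay, at which 2 of the 3 values shown sit, sits at both values. From compound 1 to compound 3 the change is acetyl in place of hydrogen on a nitrogen on an aromatic ring, which gives an at least 100-fold higher number from compound 1 to compound 3 (2.00 log units; beyond the scatter) between the limit of < 1 nM in this assay, at which 2 of the 3 values shown sit, and (the limit of > 100 nM in this assay, at which 1 of the 3 values shown sits).

Compound 4 `CC(=O)Nc1ccc(-c2nc3ccccc3s2)cc1I` is not yet measured. It differs from compound 3 by iodo in place of bromo on an aromatic carbon. This is the same kind of change as that from compound 1 to compound 2, but the place is not the same: there the iodo enters ortho to an amino group of one heavy atom, here ortho to an acetamido group of four heavy atoms. For this assay the step from compound 3 to compound 4 is expected to be a step that the limit leaves unreadable from compound 3 to compound 4, resting on the reading that the step from compound 1 to compound 2 is unreadable while compound 3 gives > 100 nM. Compound 4 is therefore estimated at 300 nM, between 100 nM and 3000 nM, with a limit likely again.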

Compound 4, half-maximal inhibitory concentration: > 100 nM
Compound 4: only a limit was reported; the forecaster's own chance of this, stated with the estimate: 60%; the middle value is on the limit's open side.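

In this assay, acetyl in place of hydrogen on the nitrogen acts on the iodo pair as it did on the bromo pair, giving an at least 100-fold higher number from compound 2 to compound 4 (2.00 log units; beyond the scatter). Set beside the earlier step, the change carries over from one core to the other in the same direction: the same change on two cores in this assay, an at least 100-fold higher number (2.00 log units; beyond the scatter) from compound 1 to compound 3 and an at least 100-fold higher number (2.00 log units; beyond the scatter) from compound 2 to compound 4; the limit leaves it open whether they differ. Both steps rest on limits of the assay and not on numbers, so the two pairs show that the higher number appears with bromo and with iodo, but not that it is equally large with each, and the steps from bromo to iodo cannot be read in either pair.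

The compounds shown leave open how far the true values of the two amines and the two acetamides lie beyond their limits, so no order of bromo and iodo can be drawn within either pair. They also leave open whether the same step would appear with a longer acyl chain or a methyl group on the nitrogen, or with chloro or fluoro in place of bromo and iodo.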